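Two ring stereocentres inverted in a phosphoserine ester

The compounds below may be only part of what the source reports. "The series", "measured", "known", "first", "only" and "open" are said of these compounds alone.

Compound 2 `CCCCCCCCCCCOc1ccccc1CCC(=O)O[C@@H]1CCOC[C@H]1OP(=O)(O)OC[C@H](N)C(=O)O` was tested in an assay on HEK293 cells for agonist activity at probable G-protein coupled receptor 34 (Mus musculus), with a stated time of 1 h (a higher number here means a larger maximal response, a lower number a smaller maximal response), and gives 10.3%. Going by the values given here, its only measured neighbour is compound 1 `CCCCCCCCCCCOc1ccccc1CCC(=O)O[C@@H]1CCOC[C@@H]1OP(=O)(O)OC[C@H](N)C(=O)O`, which in this assay gives 8.9%; the step between them, a number 1.4 percentage points higher from compound 1 to compound 2 (within the scatter), is the whole of what has been measured, and of that pair the one recorded fact is the fact that one of compounds 1 and 2 is drawn with a defined configuration and the other without, at the place where they differ. Compound 3 `CCCCCCCCCCCOc1ccccc1CCC(=O)O[C@H]1CCOC[C@@H]1OP(=O)(O)OC[C@H](N)C(=O)O` has not yet been measured. It differs from compound 2 in this way: the two compounds have the same atoms and bonds; at least one stereo element is drawn with a configuration in one of them and without one in the other: 2 of 4 stereo elements differ; a stereocentre at a saturated ring carbon is drawn R in compound 2 and S in compound 3; a stereocentre at a saturated ring carbon is drawn R in compound 2 and S in compound 3. Among the compounds with values here, the one measured step, a change at a single stereocentre at a saturated ring carbon, stayed within the scatter, so the double change in compound 3 gives no measured ground to expect a step beyond the scatter in either direction. The expected step from compound 2 to compound 3 is therefore a number 0.7 percentage points lower from compound 2 to compound 3 (within the scatter). In this assay compound 3 is estimated at 9.6%, in a range from 3% to 20%.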

Compound 3, largest response reached (Emax), in percent of the reference or control that the assay uses: "not active" (no number reported)
Nothing numeric was reported for compound 3, so the estimate cannot be set against anything.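

In this assay, going by these compounds alone, compound 3 is reported only as not active, without a number, so no step from compound 2 to compound 3 can be read. Still open, on these data alone, is how compound 3's maximal response compares numerically, and what each of its two changed ring stereocentres contributes alone.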